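This account rests on a few compounds, and the source may have more. Where it says the series, first, only, none or still open, it means among the compounds named here.

Measured so far in a functional assay on SK-OV-3 cells (Homo sapiens) for antiproliferative activity, read by MTT assay, with a stated time of 48 h; on this read-out higher numbers stand for weaker inhibition and lower numbers for stronger inhibition
- compound 1 `Cc1c(Cc2ccccc2)c(=O)oc2cc(OCCOc3no[n+]([O-])c3S(=O)(=O)c3ccccc3)ccc12` gives 17.3 nM
- compound 2 `COc1cc(OCCOc2no[n+]([O-])c2S(=O)(=O)c2ccccc2)ccc1C(=O)/C=C/c1ccc(F)cc1` gives 25 nM

Compound 2, at 25 nM, lies within the usual scatter of compound 1, so these two numbers cannot be told apart. Compound 3 `COc1cc(OCCOc2no[n+]([O-])c2S(=O)(=O)c2ccccc2)ccc1C(=O)/C=C/c1ccccc1` differs from compound 2 in one place: hydrogen in place of fluoro on an aromatic carbon. Going by the values given here, no measured pair shows what this swap does, so no step beyond the scatter is expected in this assay, and no direction is favoured. The estimated change is a 1.1-fold higher number from compound 2 to compound 3 (0.05 log units; within the scatter), a small one. Compound 3 is expected at 28 nM, with an estimated range from 11 nM to 70 nM.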

Compound 3, half-maximal inhibitory concentration: 35.8 nM
Estimate against measurement, compound 3: 1.3-fold (0.11 log units) below; the measured number falls inside the stated range.
By their numbers in this assay, from the lowest: compounds 1, 2 and 3 (each within the scatter of the next, the first and the last beyond it).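

In this assay, going by these compounds alone, hydrogen in place of fluoro on this aromatic carbon gives a 1.4-fold higher number from compound 2 to compound 3 (0.16 log units; within the scatter), the first single-place step. On these numbers, 4-fluorophenyl and phenyl cannot be told apart at this position, so the fluoro group shows no readable effect on antiproliferative activity here. No measurement at hand offers an explanation for this result.

The compounds shown leave open whether another group at this place, such as chloro, methoxy or an amine, would give a step beyond the scatter. They also leave open whether fluoro elsewhere on this ring would behave the same way.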